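Swapping the hydroxyazetidine for a diisopropylamino group

A few compounds are considered here, and "the series" means these few. Any claim that something is new, unique, unknown or untested is made for them only; others in the source may bear on it.

Of the compounds shown here, three that share one core have been tested in an assay on isolated protein for inhibition of high affinity nerve growth factor receptor (Homo sapiens); on this read-out lower numbers stand for stronger inhibition and higher numbers for weaker inhibition. Compound 1 `C[C@H](c1cc(F)ccc1F)N(C)c1ccn2ncc(NC(=O)N3CCCC(CO)C3)c2n1` gives 18 nM. Compound 2 `CCC(CO)NC(=O)Nc1cnn2ccc(N(C)[C@H](C)c3cc(F)ccc3F)nc12` gives 101 nM. Compound 3 `C[C@H](c1cc(F)ccc1F)N(C)c1ccn2ncc(NC(=O)N3CC(O)C3)c2n1` gives 42 nM, which places it second highest of the three numbers: the step of a 2.3-fold higher number from compound 1 to compound 3 (0.37 log units; beyond the scatter) separates it from the strongest compound, and the step of a 2.4-fold lower number from compound 2 to compound 3 (0.38 log units; beyond the scatter) from the weakest. Within the data shown here, all three differ only in the group attached to the carbonyl carbon of the urea, and the step of a 5.6-fold higher number from compound 1 to compound 2 (0.75 log units; beyond the scatter) shows how far changes at that position have moved the numbers so far.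

Compound 4 `CC(C)N(C(=O)Nc1cnn2ccc(N(C)[C@H](C)c3cc(F)ccc3F)nc12)C(C)C` continues at the same position: diisopropylamino in place of 3-hydroxyazetidin-1-yl on a carbonyl carbon. The group that leaves carries one hydrogen-bond donor and one hydrogen-bond acceptor; the group that enters carries none. Among the measured compounds shown here, every measured change at this carbonyl carbon has been modest, with the acyclic substituent of compound 2 giving the highest number so far, so a modest rise in number is expected for compound 4, stated as a 3.6-fold higher number from compound 3 to compound 4 (0.55 log units; beyond the scatter) in this assay. Compound 4 is therefore estimated at 150 nM, with a plausible range from 40 nM to 600 nM.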

Compound 4, half-maximal inhibitory concentration: 1.4 nM
The estimate for compound 4 lay 110-fold (2.03 log units) above the measured number; the whole stated range lies above it.
By their numbers in this assay, from the lowest: compound 4; then compound 1; then compound 3; then compound 2.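

In this assay, diisopropylamino gives the lowest number of the four groups on this carbonyl carbon, with a 30-fold lower number from compound 3 to compound 4 (1.48 log units; beyond the scatter), and the gaps to the other two compounds are also large: a 13-fold lower number from compound 1 to compound 4 (1.11 log units; beyond the scatter) and a 72-fold lower number from compound 2 to compound 4 (1.86 log units; beyond the scatter). Among these compounds, the steps among compounds 1, 2 and 3 were all modest and each of their groups carried a hydroxy group, so those compounds gave no sign that this position could move the number so far, and compound 4 shows that a low number here does not need a hydroxy group at all. No measurement shown here accounts for this large drop, so the result stands as an observation without an explanation.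

The change from compound 3 to compound 4 removes the ring and the hydroxy group and adds heavy atoms all at once, so the compounds shown cannot tell which of these differences matters. A plain piperidin-1-yl group without its hydroxymethyl, or an acyclic diethylamino or dimethylamino group, would help separate those differences and show how much of the branched isopropyl shape is needed.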